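The source may hold more compounds than are shown below. What is called first, only, known or untested is meant among the compounds shown, and "the series" means these compounds.

Among the compounds with values here, compound 2 `CNc1nnc(-c2nsc3ccccc23)o1` stands highest of the two numbers so far measured in a functional assay on the whole organism for inhibition, with Rattus norvegicus as the target, with a stated time of 3.5 h, at a dose of 100 mg/kg by the intraperitoneal route (on this read-out lower numbers stand for less inhibition and higher numbers for more inhibition at the one dose given (going by the name of the read-out)), where compound 2 gives 60%. Compound 1 `CCc1nnc(-c2nsc3ccccc23)o1` gives 10% in this assay, and the step of a number 50 percentage points higher from compound 1 to compound 2 (beyond the scatter) came with methylamino in place of ethyl on an aromatic carbon. Compound 3 `CCNc1nnc(-c2nsc3ccccc23)o1` differs from compound 2 by methyl in place of hydrogen on a saturated chain carbon bound to a nitrogen on an aromatic ring. Within the data shown here, no measured step concerns a change of this kind; the single step measured swapped one whole group for another rather than lengthening a chain on a nitrogen. The expected step of a number 5 percentage points lower from compound 2 to compound 3 (within the scatter) is therefore small, within the scatter. Compound 3 is estimated at 55% in this assay, between 30% and 75%.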

Compound 3, a percentage reported as inhibition, in the whole organism at one dose (the size of the read-out at that dose, not a potency): 42%
For compound 3 the middle estimate is 13 percentage points above the measured one; low and high end bracket the measured number.
By their numbers in this assay, from the lowest: compound 1; then compound 3; then compound 2.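

In this assay, the nitrogen's chain is sensitive to a small change: methyl in place of hydrogen gives a number 18 percentage points lower from compound 2 to compound 3 (beyond the scatter), so a single added carbon here moves the result beyond the scatter. Ethylamino in place of ethyl still gives a number 32 percentage points higher from compound 1 to compound 3 (beyond the scatter), so the gain from a nitrogen-linked group survives the longer chain, though it is smaller. As far as these compounds go, whether a propylamino chain or a plain amino group on the same aromatic carbon would continue this trend remains open. No measurement at hand accounts for the drop from methylamino to ethylamino.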